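Working notes: sulfonyl replacement on the shared core

The source may report more compounds than this note shows. Statements on the series, on what has been measured and on what is new or still open speak of the compounds shown alone.

Two compounds of the series have numbers in a functional assay on DU-145 cells (Homo sapiens) for inhibition, read by trypan blue exclusion, with a stated time of 72 h; a higher number here means a weaker inhibitor, a lower number a stronger inhibitor. Compound 1, `Cn1c(=O)c(S(=O)(=O)c2ccc(Cl)cc2Cl)cc2cnc(Nc3ccc4[nH]ccc4c3)nc21`, gives 1000 nM in this assay, the lowest of the two numbers. Compound 2, `Cn1c(=O)c(S(=O)(=O)c2ccccc2)cc2cnc(Nc3ccc4cc[nH]c4c3)nc21`, gives 10000 nM in this assay, a number beyond the scatter from that of compound 1. Within the data shown here, compound 2 differs from compound 1 in more than one place, so the two values show only that compound 1 is the stronger inhibitor of the pair, not which change carries the gap.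

Compound 3, `Cn1c(=O)c(S(=O)(=O)Nc2ccc(F)cc2)cc2cnc(Nc3ccc4[nH]ccc4c3)nc21`, is not yet measured. It differs from compound 1 in one place: (4-fluorophenyl)amino in place of 2,4-dichlorophenyl on a sulfonyl sulfur. Cut one bond further out, the same difference reads (2,4-dichlorophenyl)sulfonyl to (4-fluorophenyl)sulfamoyl. Among the measured compounds shown here, no measured pair changes this group, so the size of the step has no precedent here. The step from compound 1 to compound 3 is expected to be small, within the scatter or a modest move towards a weaker inhibitor, as a 1.6-fold higher number from compound 1 to compound 3 (0.20 log units; within the scatter). Compound 3 is therefore expected to give 1600 nM in this assay, with a range from 400 nM to 6000 nM.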

Compound 3, half-maximal inhibitory concentration: 5000 nM
Beside the measured number, compound 3's estimate is 3.1-fold (0.49 log units) below it; the measured number falls inside the stated range.
By their numbers in this assay, from the lowest: compound 1; then compounds 3 and 2 (each within the scatter of the next).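

In this assay, among these compounds, a 5.0-fold higher number from compound 1 to compound 3 (0.70 log units; beyond the scatter) is the first step that changes one place only, and it shows that the group on the sulfonyl sulfur affects the number: replacing 2,4-dichlorophenyl with (4-fluorophenyl)amino moves it beyond the scatter, towards a weaker inhibitor. The heavy-atom count and the carbon-only aromatic ring stay the same, while the chlorines leave and a fluorine, a nitrogen and a hydrogen-bond donor enter, so this single step bundles several differences and cannot assign the loss to any one of them. Nothing available on these compounds accounts for the step.

Still open, going by these compounds, is whether the nitrogen or the change in halogens carries the gap, which (2,4-dichlorophenyl)amino or a 4-fluorophenyl set directly on the sulfonyl sulfur would help to separate. Also open, on these data alone, is whether an aromatic ring is needed at this position at all, and whether a cyclohexyl or methyl group on the sulfonyl sulfur would keep a number close to that of compound 1, 1000 nM in the same read-out.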